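This account rests on a few compounds, and the source may have more. Where it says the series, first, only, none or still open, it means among the compounds named here.

Measured compounds in the series:

- compound 1, `COC(=O)c1c(O)c(F)c(F)c(F)c1F`: 0%
- compound 2, `COC(=O)c1cc(F)c(F)c(F)c1O`: 0%
- compound 3, `CC(=O)Oc1c(F)c(F)c(F)c(F)c1C(=O)O`: 0%

All three values come from a toxicity assay on the whole organism (strain CD-1) for cytotoxicity, with Mus musculus as the target, with a stated time of 14 days, at a dose of 300 mg/kg by the intraperitoneal route; on this read-out lower numbers stand for a stronger effect and higher numbers for a weaker effect at the one dose given. Compound 1 gives 0% in this assay, compound 2 gives 0%, and compound 3 gives 0%; the three stand level with one another at the digits recorded, and no ordering among them can be read from these numbers.

Among the measured compounds shown here, the one measured step, from compound 1 to compound 2, is hydrogen in place of fluoro on an aromatic carbon and gave no change at the digits printed from compound 1 to compound 2 (within the scatter). Compound 3 and compound 1 share no single counted difference; the difference between the two cores is not broken down here.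

The unmeasured compound 4, `CC(=O)Oc1c(C(=O)O)cc(F)c(F)c1F`, arises from compound 3 by hydrogen in place of fluoro on an aromatic carbon. For the measured compounds named here, this is the same kind of change as the one from compound 1 to compound 2, but not the same: in compound 3 the site is ortho to a carboxy group and meta to an acetoxy group, whereas in compound 1 it is ortho to a methoxycarbonyl group and meta to a hydroxy group; the remaining surroundings, ortho to a fluoro group, meta to a fluoro group and para to a fluoro group, read alike.

For compound 4 in this assay a step of no change at the digits printed from compound 3 to compound 4 (within the scatter) is expected, resting on the earlier step of no change at the digits printed from compound 1 to compound 2 (within the scatter) and on the level value of compound 3, 0%. On that basis compound 4 is estimated at 0%, within 0% to 10%.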

Compound 4, a percentage reported as activity, at one dose (the size of the read-out at that dose, not a potency): 0%
The estimate for compound 4 equals the measured number at the digits printed; low and high end bracket the measured number.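

In this assay, hydrogen in place of fluoro on an aromatic carbon gave no change at the digits printed from compound 3 to compound 4 (within the scatter), and set beside the earlier step, the change reads alike on the two cores: the same change on two cores in this assay, no change at the digits printed (within the scatter) from compound 1 to compound 2 and no change at the digits printed (within the scatter) from compound 3 to compound 4, 0 percentage points apart, within the scatter of two such steps

So in this series, the change carries from the core of compound 1 to the core of compound 3 without any visible difference, even though the site has a carboxy group and an acetoxy group around it in one case and a methoxycarbonyl group and a hydroxy group in the other. Among the compounds shown here, the agreement rests on only two steps, and all four compounds stand level at the single dose given, so neither step shows the change moving the read-out. It therefore cannot show how the change would carry over on a compound whose read-out stands away from this level, or at another dose.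

The compounds shown leave open whether the read-out stays level when an amine or a chloro group, rather than hydrogen, takes the place of the fluoro group, or when a longer chain stands in place of the acetoxy group. Also open, on these data alone, is what a second hydrogen in place of fluoro on either core would do.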